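This account rests on a few compounds, and the source may have more. Where it says the series, first, only, none or still open, it means among the compounds named here.

Compound 1 `CCN(C(=O)OC)c1c(N)nc(-c2nn(Cc3ccccc3F)c3ncccc23)nc1N` gives 0.2 uM in an assay on cells for activation of Guanylate cyclase soluble subunit alpha-1 (Rattus norvegicus), read by cGMP accumulation and immunoassay, with a stated time of 10 min; a higher number here means that more compound is needed for the effect, a lower number that less compound is needed.
Compound 2 `CC(C)OC(=O)Nc1c(N)nc(-c2nn(Cc3ccccc3F)c3ncccc23)nc1N` gives 0.8 uM in this assay.

Compound 2 stands highest of these two numbers, set apart from compound 1 by the step of a 4.0-fold higher number from compound 1 to compound 2 (0.60 log units; beyond the scatter). Compound 3 `Nc1nc(-c2nn(Cc3ccccc3F)c3ncccc23)nc(N)c1NC(=O)OC1COC1` differs from compound 2 by oxetan-3-yl in place of isopropyl on an oxygen next to a carbonyl group. For the measured compounds named here, that single measured step is the only guide, and it swaps a different group at this position, so it gives only a rough sense of scale. A small shift is expected, likely within the scatter, with no clear direction; the expected step is a 1.3-fold higher number from compound 2 to compound 3 (0.10 log units; within the scatter). Compound 3 is estimated at 1 uM, with a range from 0.3 uM to 3 uM.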

Compound 3, minimum effective concentration: 2.3 uM
Compound 3: middle estimate off by 2.3-fold (0.36 log units), on the low side; low and high end bracket the measured number.
By their numbers in this assay, from the lowest: compound 1; then compound 2; then compound 3.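

Putting oxetan-3-yl in place of isopropyl on an oxygen next to a carbonyl group gives a 2.9-fold higher number from compound 2 to compound 3 (0.46 log units; beyond the scatter) in this assay, so the group at this position affects the result even when the change is small. The change from the side group of compound 1 to that of compound 3 is larger, with a 12-fold higher number from compound 1 to compound 3 (1.06 log units; beyond the scatter) as the widest gap among the three compounds. No measurement at hand explains these shifts.

The compounds shown leave open whether the ring or its oxygen matters more. A cyclobutyl group on the same oxygen would help separate the two.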